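A few compounds are considered here, and "the series" means these few. Any claim that something is new, unique, unknown or untested is made for them only; others in the source may bear on it.

Three thiosemicarbazide-type compounds have been measured. Compound 1 `N/C(=N\NC(=S)N1CCOCC1)c1ccccn1` gives 43.1% in a functional assay on A-431 cells (Homo sapiens) for cytotoxicity, read by MTT assay, with a stated time of 72 h, tested at 3 uM; a lower number here means less inhibition of growth, a higher number more inhibition of growth at the concentration tested. Compound 3 `Cc1cccc(/C(N)=N/NC(=S)N2CCOCC2)n1` gives 45.8% in this assay, and the change from compound 3 to compound 1, (hydrogen in place of methyl on an aromatic carbon), gave a number 2.7 percentage points lower from compound 3 to compound 1 (within the scatter). Compound 2 `Cc1ccnc(/C(N)=N/NC(=S)N2CCN(c3ccccn3)CC2)c1` gives 34.7% in this assay, the lowest of the three numbers; the difference between its core and that of compound 3 is not broken down here.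

Compound 4 `N/C(=N\NC(=S)N1CCN(c2ccccn2)CC1)c1ccccn1` has not yet been measured. It differs from compound 2 by hydrogen in place of methyl on an aromatic carbon, the same kind of change as from compound 3 to compound 1, though there the place was next to the ring nitrogen, whereas here it is opposite the ring nitrogen. The step is expected to be a number 1.7 percentage points lower from compound 2 to compound 4 (within the scatter), resting on the earlier step of a number 2.7 percentage points lower from compound 3 to compound 1 (within the scatter) from compound 3 to compound 1. Compound 4 is therefore estimated at 33% in this assay, between 21% and 46%.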

Compound 4, percent growth inhibition at one concentration: 45.8%
Compound 4: the middle estimate sits 12.8 percentage points below what was measured; the range from low to high includes it.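

In this assay, hydrogen in place of the methyl opposite the ring nitrogen gave a number 11.1 percentage points higher from compound 2 to compound 4 (beyond the scatter). Set beside the earlier pair, this step cannot be told apart from it: the same change on two cores in this assay, a number 2.7 percentage points lower (within the scatter) from compound 3 to compound 1 and a number 11.1 percentage points higher (beyond the scatter) from compound 2 to compound 4, 13.8 percentage points apart, within the scatter of two such steps. For the compounds shown here, the two pairs therefore give no firm sign that the change behaves differently on the two cores, but they also do not show that it carries over, as there are only two pairs and the methyl stands at a different place on the ring in each.

The compounds shown carry only methyl or hydrogen on this ring. From the compounds shown here alone, whether a chlorine, a methoxy group or an amine at the same place would behave like the methyl remains open.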